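The compounds below may be only part of what the source reports. "The series", "measured", "known", "first", "only" and "open" are said of these compounds alone.

Working notes on the series.

Compound 1 `O=S(=O)(/C=C\c1ccc(Cl)nc1)c1cccc(F)c1` gives 965 nM in an assay on U2OS cells for activation of nuclear factor erythroid 2-related factor 2 (Homo sapiens), read by beta-arrestin recruitment, with a stated time of 6 h; a higher number here means that more compound is needed for the effect, a lower number that less compound is needed. Compound 3 `O=S(=O)(/C=C\c1ccc(Cl)nc1)c1cccc(Cl)c1` differs from compound 1 by chloro in place of fluoro on an aromatic carbon; in this assay compound 3 gives 3390 nM, so the change produces a 3.5-fold higher number from compound 1 to compound 3 (0.55 log units; beyond the scatter). Compound 2 `O=S(=O)(/C=C/c1ccc(Cl)nc1)c1ccc(F)cc1` has the same atoms as compound 1, joined differently; the difference between the two cores is not broken down here. In this assay compound 2 gives only a limit, > 10000 nM, which is the limit of > 10000 nM in this assay, at which 1 of the 3 values shown sits. Compound 4 `O=S(=O)(/C=C/c1ccc(Cl)nc1)c1ccc(Cl)cc1` is not yet measured in this assay and differs from compound 2 by chloro in place of fluoro on an aromatic carbon. This is the same kind of change as that from compound 1 to compound 3, though the place differs: meta to a large group there, para to a large group here. The step is expected to be a step that the limit leaves unreadable from compound 2 to compound 4, resting on compound 1 and compound 3 showing a 3.5-fold higher number from compound 1 to compound 3 (0.55 log units; beyond the scatter). Compound 4 is therefore expected near 30000 nM, with a range from 10000 nM to 100000 nM, and most probably again only a limit.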

Compound 4, half-maximal effective concentration: > 10000 nM
Compound 4: no number, only a limit; the forecaster's own chance of this, stated with the estimate: 85%; the middle value is on the limit's open side.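

Compound 2 and compound 4 each give only a limit in this assay, so no step can be read between them: the limit of > 10000 nM in this assay, at which 2 of the 4 values shown sit.

Still open, as far as these compounds go, is whether chloro in place of fluoro, para to a large group, changes the number at all.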